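Hydroxy for Hydroxymethyl on a Shared Core

The source may report more compounds than this note shows. Statements on the series, on what has been measured and on what is new or still open speak of the compounds shown alone.

Of the compounds shown here, three sharing one core have been measured in a functional assay on the whole organism with Rattus norvegicus as the target, read by paw edema, with a stated time of 3 h, at a dose of 100 mg/kg by the oral route; a lower number here means less inhibition, a higher number more inhibition at the dose given (going by the name of the read-out). Compound 1 `CCc1ccc(-c2nc3ccccc3[nH]2)nc1` gives 44%. Compound 2 `OCc1cccc(-c2nc3ccccc3[nH]2)n1` gives -13%, and compound 3 `CCOC(=O)c1ccc(-c2nc3ccccc3[nH]2)nc1` gives -16%. Among these three numbers compound 2 stands second highest; its nearest neighbour is compound 3, a number within the scatter of it, while compound 1 lies well beyond the scatter above it. Within the data shown here, the only step between measured compounds that differ in one place is a number 60 percentage points lower from compound 1 to compound 3 (beyond the scatter), a large change.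

Compound 4 `Oc1cccc(-c2nc3ccccc3[nH]2)n1` has not yet been measured. It differs from compound 2 in one place: hydroxy in place of hydroxymethyl on an aromatic carbon. The group sits on an aromatic carbon of a six-membered aromatic ring with one nitrogen, next to the ring nitrogen.

Among the measured compounds shown here, no measured step involves a hydroxymethyl or a hydroxy group, so the step from compound 1 to compound 3 does not bear directly on this change; the data give no guide of their own. The expectation therefore rests on compound 2 alone, and the estimated step of a number 3 percentage points higher from compound 2 to compound 4 (within the scatter) is expected to stay within the scatter. Compound 4 is estimated at -10%, within a range from -35% to 15%.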

Compound 4, a percentage reported as inhibition, in the whole organism at one dose (the size of the read-out at that dose, not a potency): -7%
Compound 4: middle estimate off by 3 percentage points, on the low side; the measured number falls inside the stated range.
By their numbers in this assay, from the lowest: compounds 3, 2 and 4 (each within the scatter of the next); then compound 1.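

In this assay, replacing hydroxymethyl with hydroxy on an aromatic carbon next to the ring nitrogen gives a number 6 percentage points higher from compound 2 to compound 4 (within the scatter) and is the first step shown at this place on the shared core. Among these compounds, the one earlier step, from ethyl to ethoxycarbonyl, was large and concerned a different group, whereas this change removes only the carbon of hydroxymethyl, going from 2 heavy atoms to 1, and leaves the read-out within the scatter. At this place and dose, then, the two oxygen-bearing groups cannot be told apart, though that holds for this pair alone and says nothing about other groups or places. No evidence in hand bears on why the two compounds read alike.

The compounds shown leave open whether an amine, a carboxylic acid or a longer chain such as ethyl at this same place would also stay within the scatter of compound 2 at -13% or move the number. They also leave open what hydroxy or hydroxymethyl would give at the place that carries ethyl in compound 1, which stands at 44% in this assay.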